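This account rests on a few compounds, and the source may have more. Where it says the series, first, only, none or still open, it means among the compounds named here.

Measured in a functional assay on MIA PaCa-2 cells (Homo sapiens) for cytotoxicity, read by WST assay, with a stated time of 48 h; on this read-out higher numbers stand for weaker inhibition and lower numbers for stronger inhibition:
- compound 1 `COc1ccc2[nH]cc(/C=C(\C#N)C(=O)c3c[nH]c4ccccc34)c2c1`: 25100 nM
- compound 2 `N#C/C(=C\c1cn(Cc2ccc(Cl)cc2)c2ccc(Br)cc12)C(=O)c1c[nH]c2ccccc12`: > 50000 nM (a limit)
- compound 3 `COc1ccc2[nH]cc(/C=C(\C#N)C(=O)c3c[nH]c4cc(F)ccc34)c2c1`: > 50000 nM (a limit)

Compound 3 has no number of its own, only the limit > 50000 nM. That places it at the limit of > 50000 nM in this assay, at which 2 of the 3 values shown sit.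

Compound 4 `COc1ccc2c(C(=O)/C(C#N)=C/c3c[nH]c4ccc(OC)cc34)c[nH]c2c1` differs from compound 3 by methoxy in place of fluoro on an aromatic carbon. For the measured compounds named here, the one measured step at this carbon is an at least 1.9-fold higher number from compound 1 to compound 3 (0.29 log units; that floor lies within the scatter). It rests on a limit, so it gives only a floor and does not show a real change on adding fluoro. Going by the values given here, no measured step places methoxy on this carbon, so the size of the methoxy change is not directly supported.

Among the compounds with values here, compound 1, with hydrogen on this carbon, gives 25100 nM, the only true number in the set. In this assay, compound 4 is therefore expected to lie near that value or at the limit, with no clear step beyond the scatter. The expected change is an at least 1.6-fold lower number from compound 3 to compound 4 (0.22 log units; that floor lies within the scatter), and this estimate is loose.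

For compound 4 the estimated value is 30000 nM, with an expected range of 5000 nM to 50000 nM.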

Compound 4, half-maximal inhibitory concentration: > 50000 nM
Compound 4: a limit, no number (the forecaster's own chance of this, stated with the estimate: 45%); middle value at least 1.6-fold (0.22 log units) from the limit.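

In this assay compound 4 gives only a limit, > 50000 nM, so methoxy on this aromatic carbon, like fluoro, yields no number of its own. Against hydrogen on the same carbon the change reads as an at least 1.9-fold higher number from compound 1 to compound 4 (0.29 log units; that floor lies within the scatter), which is again only a floor and shows no real change, while the step between compound 3 and compound 4 cannot be read, both values being limits. What is new is that two different groups on this carbon now end at the same limit, so the carbon has a second replacement of hydrogen with no readable value, and the series gains no further true number: the limit of > 50000 nM in this assay, at which 3 of the 4 values shown sit.

As far as these compounds go, how an amine or a carboxylic acid on this carbon would read against compound 1 at 25100 nM stays open. From the compounds shown here alone, whether methoxy and fluoro differ from hydrogen at all, or from each other, also stays open, with no true number for either compound 3 or compound 4.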